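Fluoro in place of hydrogen on compound 3

The source may report more compounds than this note shows. Statements on the series, on what has been measured and on what is new or still open speak of the compounds shown alone.

Compound 1 `CCOC(=O)C1=CCCCC1NS(=O)(=O)c1ccc(F)cc1Cl` reaches only the limit of a functional assay on RAW264.7 cells (Mus musculus), read by fluorescence (on this read-out higher numbers stand for weaker inhibition and lower numbers for stronger inhibition), and gives > 10000 nM there. Compound 2 `CCOC(=O)C1=CCCCC1S(=O)(=O)Oc1ccc(F)cc1Cl` gives 904 nM in this assay. Compound 3 `CCOC(=O)C1=CCCCC1S(=O)(=O)Cc1ccccc1` gives 101 nM in this assay, the lowest of the two numbers shown, and its gap to compound 2 lies beyond the scatter. Compound 4 `CCOC(=O)C1=CCCCC1S(=O)(=O)Cc1ccccc1F` has not been measured in this assay; it differs from compound 3 by fluoro in place of hydrogen on an aromatic carbon, ortho to a large group. Going by the values given here, no measured step shows the effect of such a change, so the expected step in this assay is a 1.1-fold lower number from compound 3 to compound 4 (0.05 log units; within the scatter), none beyond the scatter in either direction. Compound 4 is estimated at 90 nM, between 30 nM and 300 nM.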

Compound 4, half-maximal inhibitory concentration: 97 nM
The estimate for compound 4 lay 1.1-fold (0.03 log units) below the measured number; the range from low to high includes it.
By their numbers in this assay, from the lowest: compounds 4 and 3 (each within the scatter of the next); then compound 2. At a limit, above all of these: compound 1.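

Read in this assay the change from phenyl to 2-fluorophenyl gives a 1.0-fold lower number from compound 3 to compound 4 (0.02 log units; within the scatter) and so offers the one direct comparison in the series. At this aromatic carbon, ortho to a large group, fluoro in place of hydrogen leaves the two numbers within the scatter of each other. No measurement shown bears on the reason for this step.

Open, as far as these compounds go, is whether chloro, methoxy or trifluoromethyl at this place would stay within the scatter of compound 3. From the compounds shown here alone, an amine or a carboxylic acid on the same ring also remains untested in these data.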